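The source may report more compounds than this note shows. Statements on the series, on what has been measured and on what is new or still open speak of the compounds shown alone.

Measured so far in a functional assay on HEK293 cells for activation of melanin-concentrating hormone receptor 1 (Rattus norvegicus), read by inositol phosphate accumulation; on this read-out higher numbers stand for an effect only at larger amounts of compound and lower numbers for an effect already at smaller amounts:
compound 1, `CC(C)C(=O)NC1CCN(c2ccc3cc(NC(=O)CCc4ccc(C(F)(F)F)cc4)ccc3n2)C1`: 90 nM
compound 2, `O=C(CCCCCCCCCCCCc1ccc(C(F)(F)F)cc1)Nc1ccc2nc([N+]34CCC(CC3)CC4)ccc2c1`: 25 nM

Compound 1 stands at the highest of these two numbers. Compound 2 reaches 25 nM, a gap to compound 1 that lies beyond the usual scatter; the two compounds differ in more than one place, so this comparison alone does not say which part of the structure is responsible.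

Compound 3, `O=C(CCc1ccc(C(F)(F)F)cc1)Nc1ccc2nc(N3CC4CCC3C4)ccc2c1`, has not yet been measured in this assay. It differs from compound 1 in one place: a group of 7 heavy atoms (6 carbon, 1 nitrogen; one five-membered non-aromatic ring of carbon only, one five-membered non-aromatic ring with 1 hetero atom) in place of a group of 11 heavy atoms (8 carbon, 2 nitrogen, 1 oxygen; one five-membered non-aromatic ring with 1 hetero atom), on an aromatic carbon. The group that enters has no hydrogen-bond donor, unlike the group that leaves, and it is smaller.

Among the compounds with values here, no direct step of this kind has been measured. Within the data shown here, the only guide is compound 2, whose value of 25 nM comes with a bicyclic amine that also lacks an amide, but with a different chain as well, so the expectation is loose. A small step toward a lower number, not clearly beyond the scatter, is expected for the change from compound 1 to compound 3, a 1.5-fold lower number from compound 1 to compound 3 (0.18 log units; within the scatter). Compound 3 is estimated at 60 nM, expected within 15 nM to 250 nM.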

Compound 3, half-maximal effective concentration: 150 nM
Compound 3: middle estimate off by 2.5-fold (0.40 log units), on the low side, and the stated range covers the measured number.
By their numbers in this assay, from the lowest: compound 2; then compounds 1 and 3 (each within the scatter of the next).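

In this assay, replacing the 3-((isopropylcarbonyl)amino)pyrrolidin-1-yl group with the smaller group of two five-membered rings, on the aromatic carbon next to the ring nitrogen, gives a 1.7-fold higher number from compound 1 to compound 3 (0.22 log units; within the scatter), so compound 1 and compound 3 cannot be told apart. This is the only comparison shown that changes this position alone, and it indicates that the read-out stays within the usual scatter when the entering group carries no hydrogen-bond donor and no amide carbonyl. Nothing measured here explains why the two compounds read alike.

The compounds shown leave open whether a plain pyrrolidin-1-yl ring, a piperidine or a dimethylamino group on this carbon would also read like compound 1 and compound 3, and whether a free amine on the pyrrolidine ring would move the number beyond the scatter. Within the data shown here, they also leave open how the long chain of compound 2 and its charged bicyclic amine each contribute, since no one-place step connects compound 2 with either of the other compounds.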